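The compounds below may be only part of what the source reports. "The series", "measured", "known", "first", "only" and "open" are said of these compounds alone.

Compounds measured in a physicochemical assay for lipophilicity, read by HPLC (a higher number here means a more lipophilic compound, a lower number a more polar compound), so far:

- compound 1 `CCn1c(-c2cnc(C)nc2)nc2c(N[C@H]3CCN(C(=O)C4CCC4)C3)ncnc21`: 1.2
- compound 2 `CCn1c(-c2ccc(C(F)(F)F)nc2)nc2c(O[C@H]3CCN(C(=O)N4CC(OC)C4)C3)ncnc21`: 2.1
- compound 3 `CCn1c(-c2ccc(C(F)(F)F)nc2)nc2c(O[C@H]3CCN(C(=O)[C@H]4C[C@@H](OC)C4)C3)ncnc21`: 2.2

Compound 1 has the lowest number of the three in this assay. Compound 2 and compound 3 both sit well beyond the scatter above it, with compound 2 the nearer of the two. For the measured compounds named here, the only step between measured neighbours is a number 0.10 log units higher from compound 2 to compound 3 (within the scatter), a change at the carbonyl carbon of the amide.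

Compound 4 `CCn1c(-c2cnc(C)nc2)nc2c(N[C@H]3CCN(C(=O)C4CC4)C3)ncnc21` is not yet measured. It comes from compound 1 by one change: cyclopropyl in place of cyclobutyl on a carbonyl carbon. Going by the values given here, no measured step is this same change; the one measured step at a carbonyl carbon swaps a ring with a methoxy group for another ring with a methoxy group, and it stayed within the scatter. So there is no direct guide, and the expectation rests on the change itself, which trims the ring on the carbonyl carbon from four to three carbons.

Compound 4 is therefore expected to come out a little below compound 1, by about a number 0.40 log units lower from compound 1 to compound 4 (beyond the scatter) in this assay. The estimate for compound 4 is 0.8, with a plausible range from 0.4 to 1.1.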

Compound 4, distribution coefficient: 0.8
Compound 4: middle estimate and measured number agree at the digits printed; low and high end bracket the measured number.
By their numbers in this assay, from the lowest: compound 4; then compound 1; then compounds 2 and 3 (each within the scatter of the next).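

Going from cyclobutyl to cyclopropyl on a carbonyl carbon whose other neighbour is an amide-type nitrogen in a ring gives a number 0.40 log units lower from compound 1 to compound 4 (beyond the scatter) in this assay. For the compounds shown here, this is the first step at this kind of carbonyl carbon that lies beyond the scatter, whereas the only earlier one, a number 0.10 log units higher from compound 2 to compound 3 (within the scatter), did not, so a shift from a four-membered to a three-membered carbon ring can register here even though neither group carries hydrogen-bond donors or acceptors. Nothing at hand explains why the number moves with this change.

The compounds shown leave open where an isopropyl chain, a cyclopentyl ring or a dimethylamino group on this carbonyl carbon would fall. They also leave open whether the same swap gives a similar step in compounds carrying trifluoromethyl, such as compound 3.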